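Ether-to-ketone linker change in the cyclohexane acid series

The source may report more compounds than this note shows. Statements on the series, on what has been measured and on what is new or still open speak of the compounds shown alone.

Measured so far:
compound 1 `Cc1cccc(Cc2nc3cc(O[C@H]4CC[C@@H](C(=O)O)CC4)ccc3n2C)c1`: 42 nM
compound 2 `Cc1cccc(Oc2nc3cc(O[C@H]4CC[C@@H](C(=O)O)CC4)ccc3n2C)c1`: 78000 nM

In an assay on isolated protein for inhibition of Long-chain-fatty-acid--CoA ligase 1 (Homo sapiens), read by mass spectrometry, with a stated time of 90 min, in the presence of a further agent that is not named here (on this read-out higher numbers stand for weaker inhibition and lower numbers for stronger inhibition), compound 1 gives 42 nM, while compound 2 gives 78000 nM. Among the measured compounds shown here, compound 2 therefore holds the highest number of the two; its only neighbour is compound 1, and the two are separated by a 1900-fold higher number from compound 1 to compound 2 (3.27 log units; beyond the scatter).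

Compound 3 `Cc1cccc(C(=O)c2nc3cc(O[C@H]4CC[C@@H](C(=O)O)CC4)ccc3n2C)c1` is the next candidate. Against compound 2 the change is (3-methylphenyl)carbonyl in place of 3-methylphenoxy on an aromatic carbon. For the measured compounds named here, the single measured step that touches this linker is a 1900-fold higher number from compound 1 to compound 2 (3.27 log units; beyond the scatter), a large shift when the benzyl was traded for a phenoxy. Going by the values given here, no measured step runs from a phenoxy to a carbonyl linker, so the direction of the coming step rests only on the observation that a carbonyl is neither the benzyl of compound 1 nor the phenoxy of compound 2. On that basis compound 3 is expected to land between the two, estimated at 3000 nM with a range from 300 nM to 30000 nM. The expected step is thus a 26-fold lower number from compound 2 to compound 3 (1.41 log units; beyond the scatter), a recovery that falls well short of compound 1.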

Compound 3, half-maximal inhibitory concentration: > 200000 nM
Compound 3 was reported as a limit (the forecaster's own chance of this, stated with the estimate: 15%); middle value at least 66-fold (1.82 log units) from the limit.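

In this assay compound 3 gives > 200000 nM, which is a limit of the assay and not a number. Replacing the 3-methylphenoxy with (3-methylphenyl)carbonyl brings no recovery at this aromatic carbon, with an at least 2.5-fold higher number from compound 2 to compound 3 (0.40 log units; beyond the scatter), and replacing the 3-methylbenzyl gives an at least 4700-fold higher number from compound 1 to compound 3 (3.67 log units; beyond the scatter), so both replacements of the 3-methylbenzyl shown here end far from compound 1. How far compound 3 lies beyond compound 2 stays unresolved, as the reading stops at the limit: the limit of > 200000 nM in this assay, at which 1 of the 3 values shown sits.

As far as these compounds go, whether an amine linker or a longer chain in place of the 3-methylbenzyl could hold the number of compound 1 remains open. Also open, from the compounds shown here alone, is how the loss with the carbonyl linker would read with a chlorine in place of the methyl on the phenyl ring.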